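Replacing a trifluoromethylphenyl with a dimethylsulfamoylphenyl

The source may hold more compounds than are shown below. What is called first, only, known or untested is meant among the compounds shown, and "the series" means these compounds.

Of the compounds shown here, three sharing one core have been measured in a functional assay on NCI-H3122 cells (Homo sapiens) for inhibition, read by CellTiter-Glo, with a stated time of 72 h; a higher number here means a weaker inhibitor of growth, a lower number a stronger inhibitor of growth. Compound 1 `C=CC(=O)Nc1cc(Nc2ncc(Cl)c(Nc3ccccc3S(=O)(=O)C(C)C)n2)ccc1N1CCC(N2CCN(C)CC2)CC1` gives 4900 nM. Compound 2 `C=CC(=O)Nc1cc(Nc2ncc(C)c(Nc3ccccc3S(=O)(=O)C(C)C)n2)c(OC)cc1N1CCN(CC)CC1` gives 2 nM. Compound 3 `C=CC(=O)Nc1cc(Nc2ncc(Cl)c(Nc3cccc(C(F)(F)F)c3)n2)c(OC)cc1N1CCN(C)CC1` gives 770 nM, which places it second highest of the three numbers: its nearest neighbour is compound 1, whose number is higher by a margin beyond the scatter, while compound 2 lies far lower, again beyond the scatter.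

The step under consideration leads from compound 3 to compound 4 `C=CC(=O)Nc1cc(Nc2ncc(Cl)c(Nc3ccccc3S(=O)(=O)N(C)C)n2)c(OC)cc1N1CCN(C)CC1`, which is not yet measured in this assay. The change is 2-(dimethylsulfamoyl)phenyl in place of 3-(trifluoromethyl)phenyl on a nitrogen on an aromatic ring. Everything else in the molecule is kept. Going by the values given here, no step between measured compounds isolates this exact change, so the expectation rests on what the two flanking compounds show. Compound 2, which also carries a sulfonyl-substituted phenyl, gives 2 nM, and compound 1, with a sulfonyl-substituted phenyl but a different tail and no methoxy, gives 4900 nM.

Compound 4 is therefore expected to improve on compound 3, with a step from compound 3 to compound 4 of a 31-fold lower number from compound 3 to compound 4 (1.49 log units; beyond the scatter) in this assay, a change beyond the scatter. The estimate for compound 4 is 25 nM, within a range from 4 nM to 160 nM.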

Compound 4, concentration for 50% growth inhibition: 11 nM
The estimate for compound 4 lay 2.3-fold (0.36 log units) above the measured number, within the range that was stated.
By their numbers in this assay, from the lowest: compound 2; then compound 4; then compound 3; then compound 1.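

In this assay, placing 2-(dimethylsulfamoyl)phenyl in place of 3-(trifluoromethyl)phenyl on a nitrogen on an aromatic ring gives a 70-fold lower number from compound 3 to compound 4 (1.85 log units; beyond the scatter), a large step beyond the scatter. The earlier compounds shown here differed from one another in several places at once, so they could not show what this substituent contributes alone; this pair shows that the change at this one position, with the rest of the molecule kept, is enough to move the number by this much. The data hold nothing that explains the size of the step, and no measurement of any property of either group accompanies it.

The two names also differ in the number that gives the substituent's place on the phenyl, so this single step cannot separate the effect of the substituent's identity from that of its place on the ring. Going by these compounds, whether a smaller group such as a nitrile, a primary sulfonamide with its two hydrogens, or a carboxylic acid on the same phenyl would give a similar step remains open.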